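Methoxy for methyl beside the ring nitrogen

This account rests on a few compounds, and the source may have more. Where it says the series, first, only, none or still open, it means among the compounds named here.

Measured so far:
compound 1, `Cc1cccc(N2CC(C)NC(=O)N2)c1`, in an assay on RBL-1 cells for inhibition of Polyunsaturated fatty acid 5-lipoxygenase (Rattus norvegicus) (on this read-out lower numbers stand for stronger inhibition and higher numbers for weaker inhibition), compound 1 gives 19000 nM
compound 2, `Cc1cccc(N2CC(C)NC(=O)N2)n1`, in this assay compound 2 gives 3800 nM

Compound 2 holds the lowest of the two numbers obtained in this assay. Its nearest neighbour is compound 1, whose number is higher by a margin beyond the scatter of repeated measurement, so compound 2 is the stronger inhibitor of the pair. The two share the same core and differ in the six-membered aromatic ring, which in compound 2 carries one ring nitrogen.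

Compound 3, `COc1cccc(N2CC(C)NC(=O)N2)n1`, has not been measured. It differs from compound 2 by a single change: methoxy in place of methyl on an aromatic carbon. Going by the values given here, no comparable exchange has been measured here, so there is no measured step to lean on. On the evidence of compound 2 alone, a step from compound 2 to compound 3 of no more than the usual scatter is expected, in either direction; a gain or loss beyond it would be a surprise rather than a prediction.

Compound 3 is therefore expected to give about 4500 nM in this assay, within a range from 1500 nM to 14000 nM, which corresponds to an expected step of a 1.2-fold higher number from compound 2 to compound 3 (0.07 log units; within the scatter).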

Compound 3, half-maximal inhibitory concentration: 5500 nM
Compound 3: middle estimate off by 1.2-fold (0.09 log units), on the low side; the measured number falls inside the stated range.
By their numbers in this assay, from the lowest: compounds 2 and 3 (each within the scatter of the next); then compound 1.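

In this assay, methoxy in place of methyl on an aromatic carbon next to the ring nitrogen gives a 1.4-fold higher number from compound 2 to compound 3 (0.16 log units; within the scatter). Going by these compounds alone, compounds 1 and 2 spoke only to the ring nitrogen, whereas this pair is the first to test the group on this carbon: the exchange adds one oxygen and one hydrogen-bond acceptor, and the resulting step cannot be told apart from repeat measurement. The data offer nothing that would explain why the two groups read alike.

Going by these compounds, it remains open whether this carbon would accept groups of a different kind, such as an amine, a chlorine atom or a longer chain like ethoxy, with the same result as methyl and methoxy, or whether one of them would move the number beyond the scatter. It is also open whether methoxy would behave in the same way on the ring of compound 1, which lacks the ring nitrogen, since the compounds shown test this exchange only in the presence of that nitrogen.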